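From piperazin-1-yl to isopropylamino on an inactive core

This account rests on a few compounds, and the source may have more. Where it says the series, first, only, none or still open, it means among the compounds named here.

Compound 1 `Cc1cc(N2CCNCC2)nc(SCc2nc3ccccc3[nH]2)n1` was tested in a functional assay on PC-3 cells (Homo sapiens) for cytotoxicity, read by MTT assay, with a stated time of 72 h (on this read-out lower numbers stand for stronger inhibition and higher numbers for weaker inhibition), where compound 1 returns only a limit, > 100000 nM. Compound 2 `Cc1cc(Nc2cccc(C(F)(F)F)c2)nc(SCc2nc3ccccc3[nH]2)n1` likewise returns only a limit in this assay, > 100000 nM. For the measured compounds named here, both results sit at the same ceiling (the limit of > 100000 nM in this assay, at which 2 of the 2 values shown sit), so compound 1 stands level with the sole other measured compound rather than apart from it. Compound 3 `Cc1cc(NC(C)C)nc(SCc2nc3ccccc3[nH]2)n1` differs from compound 1 by isopropylamino in place of piperazin-1-yl on an aromatic carbon. Going by the values given here, no measured step connects such a pair, so the data give no size for this change. The expected step that the limit leaves unreadable from compound 1 to compound 3 is none beyond the scatter. Compound 3 is therefore estimated at about 150000 nM, with a range from 50000 nM to 500000 nM, most probably again reported only as a limit.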

Compound 3, half-maximal inhibitory concentration: > 100000 nM
Compound 3: no number, only a limit; the forecaster's own chance of this, stated with the estimate: 85%; the middle value is on the limit's open side.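

In this assay compound 3 returns only a limit (> 100000 nM). For the compounds shown here, compound 1 also returns only a limit, so no step between compound 1 and compound 3 can be read. The compounds shown leave open whether any substituent at this place on the shared core gives a measurable value: the limit of > 100000 nM in this assay, at which 3 of the 3 values shown sit.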